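From 3-cyanophenyl to 2,4-dichlorophenyl in a small series

The source may hold more compounds than are shown below. What is called first, only, known or untested is meant among the compounds shown, and "the series" means these compounds.

Measured in a functional assay (muscle tissue) with Cavia porcellus as the target; a lower number here means that less compound is needed, a higher number that more compound is needed for the effect:
- Compound 1 `COC(=O)C1=C(C)N=C(C)/C(=C(\O)OC)C1c1cccc(O)c1` gives 1000 nM
- Compound 2 `COC(=O)C1=C(C)N=C(C)/C(=C(\O)OC)C1c1ccccc1F` gives 42.7 nM
- Compound 3 `COC(=O)C1=C(C)N=C(C)/C(=C(\O)OC)C1c1cccc(C#N)c1` gives 34.7 nM

Compound 3 stands level with compound 2 at the low end of these numbers, while compound 1 lies far higher (a 29-fold lower number from compound 1 to compound 3 (1.46 log units; beyond the scatter)) and (a 23-fold lower number from compound 1 to compound 2 (1.37 log units; beyond the scatter)). For the measured compounds named here, both of those large steps start from compound 1, the only one with a hydroxy group, and compound 4 `COC(=O)C1=C(C)N=C(C)/C(=C(\O)OC)C1c1ccc(Cl)cc1Cl` has none. Compound 4 carries 2,4-dichlorophenyl in place of 3-cyanophenyl on a saturated ring carbon. The closest guide is the exchange of one hydroxy-free ring for another (a 1.2-fold lower number from compound 2 to compound 3 (0.09 log units; within the scatter)), which stayed within the scatter. So no step beyond the scatter is expected in this assay, and no direction can be called. The estimated step is small (a 1.3-fold higher number from compound 3 to compound 4 (0.11 log units; within the scatter)). For compound 4 the estimated value is 45 nM (12 nM to 170 nM).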

Compound 4, half-maximal effective concentration: 640 nM
The estimate for compound 4 lay 14-fold (1.15 log units) below the measured number; the measured number lies above the stated range.
By their numbers in this assay, from the lowest: compounds 3 and 2 (each within the scatter of the next); then compounds 4 and 1 (each within the scatter of the next).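

Among rings without a hydroxy group, the exchange at this saturated ring carbon is not neutral after all: 2,4-dichlorophenyl brings large steps (an 18-fold higher number from compound 3 to compound 4 (1.27 log units; beyond the scatter); a 15-fold higher number from compound 2 to compound 4 (1.18 log units; beyond the scatter)). Lacking a hydroxy group is therefore not enough to keep the number low, and the step against the hydroxy compound stays within the scatter (a 1.6-fold lower number from compound 1 to compound 4 (0.19 log units; within the scatter)). No measurement at hand gives a reason for these steps.

Still open, on these data alone, is which of the two chlorines goes with the higher number, a question that a phenyl ring carrying a single chlorine could address. Also open, as far as these compounds go, is where a phenyl ring bearing an amine would fall.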